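A few compounds are considered here, and "the series" means these few. Any claim that something is new, unique, unknown or untested is made for them only; others in the source may bear on it.

In a functional assay on HepG2 cells (Homo sapiens) for inhibition, read by MTT assay, with a stated time of 48 h (a lower number here means a stronger inhibitor, a higher number a weaker inhibitor), compound 1 `CCc1ccc(-c2nc3ccccn3c2Sc2ccccc2)cc1` gives 50200 nM, compound 2 `C(=C/c1nc2ccccn2c1Sc1ccccc1)\c1ccccc1` gives 8800 nM and compound 3 `CS(=O)(=O)c1ccc(-c2nc3ccccn3c2Sc2cccc3ccccc23)cc1` gives 13600 nM. Compound 2 and compound 3 lie within the scatter of each other, and the numbers of both stand under that of compound 1. Compound 4 `c1ccc(Sc2c(-c3cccs3)nc3ccccn23)cc1` has not yet been measured. It differs from compound 2 in one place, with thiophen-2-yl in place of 2-phenylethenyl on an aromatic carbon. Among the compounds with values here, the only measured step at this place is a 5.7-fold lower number from compound 1 to compound 2 (0.76 log units; beyond the scatter), with 2-phenylethenyl in place of 4-ethylphenyl. Within the data shown here, no measured compound carries thiophen-2-yl, so that step is only a rough guide. Like compound 1, at 50200 nM, compound 4 has an aromatic ring directly on that carbon, so a move back towards that number is expected in this assay, though only part of the way. The expected change is a 2.3-fold higher number from compound 2 to compound 4 (0.36 log units; beyond the scatter), a step that may not clear the scatter. For compound 4 the estimate is 20000 nM, with an expected range from 7000 nM to 55000 nM.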

Compound 4, half-maximal inhibitory concentration: 17100 nM
Compound 4: the middle estimate sits 1.2-fold (0.07 log units) above what was measured, within the range that was stated.
By their numbers in this assay, from the lowest: compounds 2, 3 and 4 (each within the scatter of the next); then compound 1.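

Measured in this assay, the change from 2-phenylethenyl to thiophen-2-yl (a 1.9-fold higher number from compound 2 to compound 4 (0.29 log units; within the scatter)) shows that the double bond outside aromatic rings is not needed at this carbon to stay within the scatter of compound 2. An aromatic ring directly on this carbon also does not by itself bring the number back towards that of compound 1, since thiophen-2-yl in place of 4-ethylphenyl gives a modest gain (a 2.9-fold lower number from compound 1 to compound 4 (0.47 log units; beyond the scatter)). No measured evidence is available to explain either step.

The compounds shown leave open whether an unsubstituted phenyl here would fall with compound 1 or with compound 4, so the ethyl group cannot be separated from the ring that carries it. They also leave open how an amine or a longer saturated chain on this carbon would read.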